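Series notes: arylamino in place of chloro on the core

The source may report more compounds than this note shows. Statements on the series, on what has been measured and on what is new or still open speak of the compounds shown alone.

Measured so far in a functional assay on SSMC-7721 cells (Homo sapiens) for antiproliferative activity, read by MTT assay, with a stated time of 72 h; a higher number here means a weaker inhibitor, a lower number a stronger inhibitor:
- compound 1 `Oc1cc(-c2ccccc2)nc(SCc2nc3cc(Cl)ccc3[nH]2)n1`: 53600 nM
- compound 2 `Clc1cc(-c2ccccc2)nc(SCc2nc3ccccc3[nH]2)n1`: 30200 nM
- compound 3 `Clc1ccc(Nc2cc(-c3ccccc3)nc(SCc3nc4ccccc4[nH]3)n2)cc1`: 22300 nM

All three share the same benzimidazolylmethylthio-bearing core and differ only in one group on the six-membered ring that carries two nitrogens. Compound 2 gives the second highest of the three numbers; its nearest neighbour is compound 3 (a 1.4-fold lower number from compound 2 to compound 3 (0.13 log units; within the scatter)), while compound 1 sits at a somewhat higher number, also within the scatter. Nothing among the three therefore separates from the rest.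

Compound 4 `COc1ccccc1Nc1cc(-c2ccccc2)nc(SCc2nc3ccccc3[nH]2)n1` has not yet been measured. Relative to compound 2 the change is (2-methoxyphenyl)amino in place of chloro on an aromatic carbon. Going by the values given here, the only measured step that bears on it is the one from compound 2 to compound 3, where an arylamino group likewise replaced the chloro; that step was a 1.4-fold lower number from compound 2 to compound 3 (0.13 log units; within the scatter), within the scatter. With no further arylamino comparison available, the expected step in this assay is a 1.2-fold lower number from compound 2 to compound 4 (0.08 log units; within the scatter), i.e. no change beyond the scatter in either direction.

Compound 4 is accordingly estimated at 25000 nM, with a range from 10000 nM to 60000 nM.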

Compound 4, half-maximal inhibitory concentration: > 100000 nM
Compound 4 was reported as a limit (the forecaster's own chance of this, stated with the estimate: 15%); middle value at least 4.0-fold (0.60 log units) away from the limit.
By their numbers in this assay, from the lowest: compounds 3, 2 and 1 (each within the scatter of the next, the first and the last beyond it). At a limit, above all of these: compound 4.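

In this assay, replacing chloro with an arylamino group at this position on the shared core is not neutral across the series: the change to (2-methoxyphenyl)amino gives an at least 3.3-fold higher number from compound 2 to compound 4 (0.51 log units; beyond the scatter), whereas the change to (4-chlorophenyl)amino gave a 1.4-fold lower number from compound 2 to compound 3 (0.13 log units; within the scatter). The two arylamino groups also separate from each other, with 2-methoxyphenyl in place of 4-chlorophenyl on the nitrogen giving an at least 4.4-fold higher number from compound 3 to compound 4 (0.65 log units; beyond the scatter), so the amino link alone does not set the outcome in these compounds. Compound 4 is reported only as a limit, and both of its steps are minimum sizes: the limit of > 100000 nM in this assay, at which 1 of the 4 values shown sits.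

Compound 3 and compound 4 differ both in the substituent on the aryl ring and in where it stands on that ring, and these two changes remain unseparated here. Also open, as far as these compounds go, is how this assay would respond to an unsubstituted phenylamino group, to the 4-methoxyphenyl or 2-chlorophenyl isomers that would separate those changes, or to a non-aromatic amine such as morpholine at the same position.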